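This account rests on a few compounds, and the source may have more. Where it says the series, first, only, none or still open, it means among the compounds named here.

Compound 1 `O=C(Nc1ccc(NC2CCCCC2)cc1Cl)c1cc(Cl)ccc1O` gives 68300 nM in an ADME assay on A549 cells (Homo sapiens) for cytotoxicity, read by resazurin assay, with a stated time of 48 h; a higher number here means that more compound is tolerated, a lower number that less compound is tolerated.
Compound 2 `O=C(Nc1ccc(NCc2ccccc2)cc1Cl)c1cc(Cl)ccc1O` gives 19700 nM in this assay.
Compound 3 `O=C(Nc1ccc(NCc2ccc(Cl)cc2)cc1Cl)c1cc(Cl)ccc1O` gives 59700 nM in this assay.

Among these three, compound 3 stands second highest: the step of a 1.1-fold lower number from compound 1 to compound 3 (0.06 log units; within the scatter) is within the scatter, so compound 1 and compound 3 cannot be told apart, while the step of a 3.0-fold higher number from compound 2 to compound 3 (0.48 log units; beyond the scatter) is beyond the scatter, so compound 3 is tolerated somewhat more than compound 2.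

Compound 4 `O=C(Nc1ccc(NCc2cnccc2Cl)cc1Cl)c1cc(Cl)ccc1O` differs from compound 3 in one place: 4-chloropyridin-3-yl in place of 4-chlorophenyl on a saturated chain carbon bound to a nitrogen on an aromatic ring. Going by the values given here, none of the measured steps makes this exact exchange. Among the compounds with values here, the steps that bear on it are the ones that vary the group on the same nitrogen, a 3.5-fold lower number from compound 1 to compound 2 (0.54 log units; beyond the scatter) and a 3.0-fold higher number from compound 2 to compound 3 (0.48 log units; beyond the scatter), both modest and in opposite directions. Changes at this position have therefore moved this assay only modestly so far. For compound 4 a step of about a 1.2-fold lower number from compound 3 to compound 4 (0.08 log units; within the scatter) is expected, small and likely within the scatter. Compound 4 is estimated at 50000 nM, with a range from 18000 nM to 130000 nM.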

Compound 4, half-maximal cytotoxic concentration: 126000 nM
Estimate against measurement, compound 4: 2.5-fold (0.40 log units) below, and the stated range covers the measured number.
By their numbers in this assay, from the lowest: compound 2; then compounds 3, 1 and 4 (each within the scatter of the next, the first and the last beyond it).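

The exchange of 4-chlorophenyl for 4-chloropyridin-3-yl, which adds one hydrogen-bond acceptor at the same heavy-atom count, changes the aromatic ring itself at this position and gives a 2.1-fold higher number from compound 3 to compound 4 (0.32 log units; beyond the scatter) in this assay as a modest rise in the concentration tolerated. Against the plain phenyl group the step is a 6.4-fold higher number from compound 2 to compound 4 (0.81 log units; beyond the scatter) and is the largest seen at this position so far, while the step of a 1.8-fold higher number from compound 1 to compound 4 (0.27 log units; within the scatter) leaves those two compounds impossible to tell apart. Nothing available explains why a ring nitrogen at this place moves the number in this direction.

Left open is whether the chloro on the new ring matters, as a pyridin-3-yl group without it would show, and whether the ring nitrogen can stand elsewhere in the ring. Also open, on these data alone, is how this assay would respond to a saturated amine such as piperidin-4-yl at this place.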